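Pyridone in Place of Hydroxymethylphenyl on the Bicyclic Lactam Core

A few compounds are considered here, and "the series" means these few. Any claim that something is new, unique, unknown or untested is made for them only; others in the source may bear on it.

Measured so far in an assay on CHO cells for displacement of a labelled ligand from Substance-P receptor (Homo sapiens); a higher number here means a weaker inhibitor, a lower number a stronger inhibitor:
Compound 1 `C[C@@H](O[C@H]1CN2C(=O)C=C(c3ccccc3)CC2[C@@H]1c1ccc(F)cc1)c1cc(C(F)(F)F)cc(C(F)(F)F)c1` gives 0.93 nM.
Compound 2 `C[C@@H](O[C@H]1CN2C(=O)C=C(c3ccc(CO)cc3)CC2[C@@H]1c1ccc(F)cc1)c1cc(C(F)(F)F)cc(C(F)(F)F)c1` gives 0.39 nM.
Compound 3 `C[C@@H](O[C@H]1CN2C(=O)C=C(c3ccncc3)CC2[C@@H]1c1ccc(F)cc1)c1cc(C(F)(F)F)cc(C(F)(F)F)c1` gives 0.14 nM.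

Compound 2 stands second highest of the three numbers: compound 1 sits a step above it, a 2.4-fold lower number from compound 1 to compound 2 (0.38 log units; beyond the scatter), and compound 3 a step below it, a 2.8-fold lower number from compound 2 to compound 3 (0.44 log units; beyond the scatter).

Compound 4 `C[C@@H](O[C@H]1CN2C(=O)C=C(c3cc[nH]c(=O)c3)CC2[C@@H]1c1ccc(F)cc1)c1cc(C(F)(F)F)cc(C(F)(F)F)c1` has not yet been measured in this assay. It differs from compound 2 in one place: a group of 7 heavy atoms (5 carbon, 1 nitrogen, 1 oxygen; one six-membered aromatic ring with 1 hetero atom) in place of a group of 8 heavy atoms (7 carbon, 1 oxygen; one six-membered aromatic ring of carbon only), on a double-bonded ring carbon.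

For the measured compounds named here, two measured steps bear on this change. Putting a ring with one hetero atom in place of the carbon-only ring gave a 6.6-fold lower number from compound 1 to compound 3 (0.82 log units; beyond the scatter), and the same kind of swap starting from the hydroxymethyl-bearing ring gave a 2.8-fold lower number from compound 2 to compound 3 (0.44 log units; beyond the scatter). The group entering compound 4 keeps one hydrogen-bond donor and one hydrogen-bond acceptor, as the leaving group does, and brings a six-membered aromatic ring with one hetero atom, as compound 3 does. A modest lowering of the number is therefore expected, of the size seen from compound 2 to compound 3, though it could also stay within the scatter.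

Compound 4 is estimated at 0.22 nM, within 0.08 nM to 0.7 nM, which means an expected step of a 1.8-fold lower number from compound 2 to compound 4 (0.25 log units; within the scatter).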

Compound 4, half-maximal inhibitory concentration: 0.27 nM
Estimate against measurement, compound 4: 1.2-fold (0.09 log units) below; the measured number falls inside the stated range.
By their numbers in this assay, from the lowest: compounds 3, 4 and 2 (each within the scatter of the next, the first and the last beyond it); then compound 1.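

At this double-bonded ring carbon, in this assay, the group entering compound 4 cannot be told apart from either of its nearest neighbours, with a 1.4-fold lower number from compound 2 to compound 4 (0.16 log units; within the scatter) and a 1.9-fold higher number from compound 3 to compound 4 (0.29 log units; within the scatter), even though compound 2 and compound 3 are themselves separated by a step beyond the scatter. For the compounds shown here, the comparison with the plain phenyl ring gives a 3.4-fold lower number from compound 1 to compound 4 (0.54 log units; beyond the scatter), so compound 1 remains the only compound set apart from all the others, and each of the three groups replacing its phenyl gives a lower number by a step beyond the scatter. No measurement at hand accounts for why these rings give the numbers they do.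

The compounds shown leave open how this position would respond to an amine, a carboxylic acid or a longer chain ending in hydroxyl on the aromatic ring. Going by these compounds alone, they also leave open how much of the result for compound 4 belongs to its carbonyl and how much to its ring nitrogen, since no compound here carries one of these without the other on an otherwise matched ring, apart from the ring of compound 3, which has the nitrogen alone.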